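A few compounds are considered here, and "the series" means these few. Any claim that something is new, unique, unknown or untested is made for them only; others in the source may bear on it.

Measured so far in an assay on cells for displacement of a labelled ligand from 5-hydroxytryptamine receptor 7 (Homo sapiens), read by scintillation counting, with a stated time of 30 min; on this read-out lower numbers stand for stronger inhibition and higher numbers for weaker inhibition: compound 1 `O=C(CCN1CCN(c2ccccc2)CC1)N1CCN(c2ccccc2)CC1` gives 26.2 nM; compound 2 `O=C(CCN1CCN(c2cccc(Cl)c2)CC1)N1CCN(c2ccccc2)CC1` gives 32.7 nM; compound 3 `O=C(CCN1CCN(c2ccc(Cl)cc2)CC1)N1CCN(c2ccccc2)CC1` gives 462 nM.

Compound 3 stands highest of the three numbers in this assay; its nearest neighbour is compound 2 and its furthest is compound 1. Compound 4 `CCOc1ccccc1N1CCN(CCC(=O)N2CCN(c3ccccc3)CC2)CC1` differs from compound 3 by 2-ethoxyphenyl in place of 4-chlorophenyl on an amine nitrogen in a ring. Among the compounds with values here, two measured steps bear on this change, an 18-fold higher number from compound 1 to compound 3 (1.25 log units; beyond the scatter) and a 14-fold higher number from compound 2 to compound 3 (1.15 log units; beyond the scatter), both large and both tied to the 4-chlorophenyl that now leaves. Within the data shown here, no measured compound carries a 2-ethoxyphenyl, so what enters is untested. Removal of the 4-chlorophenyl is therefore expected to bring the number back down, and for compound 4 a step of a 15-fold lower number from compound 3 to compound 4 (1.19 log units; beyond the scatter) is expected. Compound 4 is estimated at 30 nM, with a range from 10 nM to 90 nM.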

Compound 4, inhibition constant: 80.3 nM
For compound 4 the middle estimate is 2.7-fold (0.43 log units) below the measured one; the measured number falls inside the stated range.
By their numbers in this assay, from the lowest: compounds 1 and 2 (each within the scatter of the next); then compound 4; then compound 3.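

Changing the group on this amine nitrogen in a ring gives a 5.8-fold lower number from compound 3 to compound 4 (0.76 log units; beyond the scatter) and so recovers part of the loss seen with 4-chlorophenyl. Compound 4 still does not reach the earlier levels: the 2-ethoxyphenyl gives a 2.5-fold higher number from compound 2 to compound 4 (0.39 log units; beyond the scatter) and the ethoxy group in place of hydrogen gives a 3.1-fold higher number from compound 1 to compound 4 (0.49 log units; beyond the scatter). This position therefore accepts a group other than chloro at a modest cost, far smaller than that of 4-chlorophenyl.

Nothing available explains these differences. As far as these compounds go, whether the cost belongs to the ethoxy group itself or to its place on the ring stays open, and a 2-methoxyphenyl or 2-chlorophenyl group could separate the two.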